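Chloro to Cyano: Expected Cell Viability for Compound 3

A few compounds are considered here, and "the series" means these few. Any claim that something is new, unique, unknown or untested is made for them only; others in the source may bear on it.

Compound 1 `O=C(N/N=C/c1ccc(Cl)cc1)c1cnccn1` was tested in an ADME assay on J774 cells (Mus musculus) for cytotoxicity, read by MTT assay, with a stated time of 48 h, tested at 50 ug/mL (a lower number here means a stronger effect, a higher number a weaker effect of the compound at the concentration tested), where compound 1 gives 83%. Compound 2 `N#Cc1ccccc1/C=N/NC(=O)c1cnccn1` carries a cyano group and, in this assay, compound 2 gives 92%. Of the two numbers, that of compound 1 is the lower, but its gap to compound 2 falls within the usual scatter of the measurement, so the two compounds read alike: both leave most cells alive at the tested concentration.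

Compound 3 `N#Cc1ccc(/C=N/NC(=O)c2cnccn2)cc1` has not yet been measured. It differs from compound 1 in a single place: cyano in place of chloro on an aromatic carbon. Going by the values given here, since no measured pair shows this exact exchange, the size of the step can only be expected, not read off. The step from compound 1 to compound 3 in this assay is expected to be small, with no change beyond the scatter, because compound 2, which also carries a cyano group, gives 92%. Compound 3 is therefore expected to give about 86%, in a range from 72% to 97%, with the expected step being a number 3 percentage points higher from compound 1 to compound 3 (within the scatter).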

Compound 3, a percentage reported as activity, at one concentration (the size of the read-out at that concentration, not a potency): 100%
Beside the measured number, compound 3's estimate is 14 percentage points below it, outside the stated range (above it).
By their numbers in this assay, from the lowest: compounds 1, 2 and 3 (each within the scatter of the next, the first and the last beyond it).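

In this assay, cyano in place of chloro on an aromatic carbon, para to a large group, gives a number 17 percentage points higher from compound 1 to compound 3 (beyond the scatter), so at this position the exchange moves the read-out toward a weaker effect on the cells. Compound 1 and compound 2 could not show this, as their two numbers lie within the scatter of each other and their groups also sit in different places. The two cyano compounds also read alike, with compound 2 at 92% and compound 3 at 100%, so these numbers show no clear difference between the two placements of the cyano group, and nothing available here explains the step from chloro to cyano.

These compounds leave open whether the step belongs to cyano in particular or would also appear with other groups at the same place, such as an amine, a carboxylic acid or a methoxy group. They also leave open whether the step would hold at another concentration or in another cell type, as all three numbers come from a single concentration in one cell line.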